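Changing the halogen pattern on the pendant ring of compound 3

The source may report more compounds than this note shows. Statements on the series, on what has been measured and on what is new or still open speak of the compounds shown alone.

Measured so far in an assay on isolated protein for inhibition of alpha-ketoglutarate-dependent dioxygenase alkB homolog 3 (Homo sapiens), read by polymerase chain reaction, with a stated time of 1 h; on this read-out lower numbers stand for stronger inhibition and higher numbers for weaker inhibition:
compound 1 `Cc1[nH]n(-c2nc3ccccc3[nH]2)c(=O)c1Cc1ccc(F)cc1` gives 600 nM;
compound 2 `Cc1[nH]n(-c2nc3ccccc3[nH]2)c(=O)c1CC(=O)O` gives 15000 nM;
compound 3 `Cc1[nH]n(-c2nc3ccccc3[nH]2)c(=O)c1Cc1ccc(Cl)cc1Cl` gives only a limit, > 10000 nM, because of the limit of > 10000 nM in this assay, at which 1 of the 3 values shown sits.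

Compound 3 thus sits at the weak end of what has been measured, with no exact number. Compound 4 `Cc1[nH]n(-c2nc3ccccc3[nH]2)c(=O)c1Cc1cccc(Cl)c1` differs from it in one place: 3-chlorophenyl in place of 2,4-dichlorophenyl on a saturated chain carbon bound to an aromatic carbon. The measured steps that touch this position are an at least 16-fold higher number from compound 1 to compound 3 (1.22 log units; beyond the scatter) and a 25-fold higher number from compound 1 to compound 2 (1.40 log units; beyond the scatter), both large losses away from the 4-fluorophenyl of compound 1. Since a 3-chlorophenyl resembles that group more than the 2,4-dichlorophenyl does, a return toward stronger inhibition is expected, an at least 4.0-fold lower number from compound 3 to compound 4 (0.60 log units; beyond the scatter). Compound 4 is therefore estimated at 2500 nM, ranging from 700 nM to 10000 nM.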

Compound 4, half-maximal inhibitory concentration: 540 nM
Beside the measured number, compound 4's estimate is 4.6-fold (0.67 log units) above it, and the stated range ends above it.
By their numbers in this assay, from the lowest: compounds 4 and 1 (each within the scatter of the next); then compound 2.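

Compound 3's loss is not shared by every chlorinated ring on this carbon: 3-chlorophenyl gives an at least 18-fold lower number from compound 3 to compound 4 (1.26 log units; beyond the scatter), and measured against the carboxy group it gives a 28-fold lower number from compound 2 to compound 4 (1.44 log units; beyond the scatter). Set against 4-fluorophenyl there is a 1.1-fold lower number from compound 1 to compound 4 (0.05 log units; within the scatter), so these two rings, each with one halogen, cannot be told apart here. Compound 3 stands only as a limit: the limit of > 10000 nM in this assay, at which 1 of the 4 values shown sits.

Going by these compounds, it remains open whether one particular chlorine of 2,4-dichlorophenyl or the pair goes with the loss. Also open, on these data alone, is how a plain phenyl, or a ring bearing an amine or a methoxy group, would fare at this place.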